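Aryl swap on the saturated ring carbon of the core

The source may hold more compounds than are shown below. What is called first, only, known or untested is meant among the compounds shown, and "the series" means these compounds.

Measured so far:
compound 1 `COc1ccc(C2OC(c3cc(OC)c(OC)c(OC)c3)=NN2C(C)=O)c(OC)c1` gives -3.1% in a functional assay on BGC-823 cells (Homo sapiens) for antiproliferative activity, read by MTT assay, tested at 5 uM; a lower number here means a weaker effect, a higher number a stronger effect of the compound at the concentration tested
compound 2 `COc1cc(C(=O)N/N=C/c2ccc(Cl)c(Cl)c2)cc(OC)c1OC` gives 32.7% in this assay

Compound 1 stands lowest of the two numbers; the nearest, compound 2, lies higher by a margin beyond the scatter. Compound 3 `COc1cc(C2=NN(C(C)=O)C(c3cccc(C(F)(F)F)c3)O2)cc(OC)c1OC` differs from compound 1 in one place: 3-(trifluoromethyl)phenyl in place of 2,4-dimethoxyphenyl on a saturated ring carbon. Within the data shown here, no measured pair that differs only in this place exists, so the size of the step is open. A modest upward step is expected in this assay, not clearly beyond the scatter; the expected step is a number 13.1 percentage points higher from compound 1 to compound 3 (beyond the scatter). For compound 3 the expected value is 10%, within -10% to 35%.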

Compound 3, a percentage reported as inhibition, at one concentration (the size of the read-out at that concentration, not a potency): 41.1%
The estimate for compound 3 lay 31.1 percentage points below the measured number; measured number above the stated range.
By their numbers in this assay, from the lowest: compound 1; then compounds 2 and 3 (each within the scatter of the next).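

In this assay the aryl group on this saturated ring carbon matters: 3-(trifluoromethyl)phenyl in place of 2,4-dimethoxyphenyl gives a number 44.2 percentage points higher from compound 1 to compound 3 (beyond the scatter) on the shared core. The two groups have the same heavy-atom count and the same ring type, but the entering group has no hydrogen-bond acceptors. Nothing measured here bears on the cause of this step.

On these data alone, whether the step comes from gaining trifluoromethyl or from losing the two methoxy groups remains open. A plain phenyl or a nitrile-bearing phenyl on this carbon would help separate the two.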